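This account rests on a few compounds, and the source may have more. Where it says the series, first, only, none or still open, it means among the compounds named here.

Compound 1 `Cc1cccc(COc2ccc(/C=C/C(/C=C/c3ccccn3)=N/Oc3ncnc4cccc(C)c34)cc2)c1` gives 97% in a functional assay on SMMC-7721 cells (Homo sapiens) for inhibition, read by MTT assay, with a stated time of 72 h, tested at 10 uM; on this read-out lower numbers stand for a weaker effect and higher numbers for a stronger effect at the one concentration tested.
Compound 2 `Cc1cccc(COc2ccc(/C=C/C(/C=C/c3ccccn3)=N/Oc3ncnc4ccccc34)cc2)c1` gives 97.5% in this assay.

Among these two numbers compound 1 stands lowest, with compound 2 as its nearest neighbour; the difference between them, a number 0.5 percentage points higher from compound 1 to compound 2 (within the scatter), is within the scatter, so the two cannot be told apart. That single step replaces a methyl on the 3-methylbenzyl part with hydrogen and leaves the read-out essentially unchanged.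

Compound 3 `Cc1cccc2ncnc(O/N=C(/C=C/c3ccc(OCc4ccccc4Cl)cc3)\C=C\c3ccccn3)c12` has not yet been tested in this assay. Compared with compound 1 it carries 2-chlorophenyl in place of 3-methylphenyl on a saturated chain carbon bound to an oxygen on an aromatic ring. Going by the values given here, the only measured step touches the same (3-methylbenzyl)oxy group, and because a number 0.5 percentage points higher from compound 1 to compound 2 (within the scatter) stayed within the scatter, a change on that group appears to matter little at this concentration. Both measured compounds also sit close to the top of the read-out, leaving little room for a rise. Compound 3 is therefore expected to score about as high as compound 1, with a step of a number 2 percentage points lower from compound 1 to compound 3 (within the scatter) that should fall within the scatter. The estimated value for compound 3 is 95%, with a range from 85% to 99.5%.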

Compound 3, a percentage reported as inhibition, at one concentration (the size of the read-out at that concentration, not a potency): 84.7%
Beside the measured number, compound 3's estimate is 10.3 percentage points above it; the whole stated range lies above it.
By their numbers in this assay, from the lowest: compound 3; then compounds 1 and 2 (each within the scatter of the next).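

Replacing 3-methylphenyl with 2-chlorophenyl on the saturated chain carbon bound to an oxygen on an aromatic ring gives a number 12.3 percentage points lower from compound 1 to compound 3 (beyond the scatter) in this assay, so this group can influence the read-out at the one concentration tested. The earlier step could not show this: its hydrogen in place of methyl lay on the shared core, while the 3-methylphenyl group stayed in place in both compounds. Nothing available explains why this swap lowers the number, and a single pair cannot support a rule about this group.

The swap removes a methyl and brings in a chlorine, with the two names also giving different numbers for the ring position, so the compounds shown cannot say which of these differences matters. A plain phenyl, 2-methylphenyl or 3-chlorophenyl group in this place would help to separate them, and a methoxy or an amine on the ring would show whether groups of a quite different kind are tolerated here.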